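Aryl Exchange on a Thioether Pair, Antiproliferative Read-Out

The compounds below may be only part of what the source reports. "The series", "measured", "known", "first", "only" and "open" are said of these compounds alone.

Measured compounds:
compound 1 `Cc1nc(-c2ccc(Cl)cc2)sc1C(=O)CSc1nc(-c2ccc(Cl)c(Cl)c2)c(C#N)c(=O)[nH]1` — 101%
compound 2 `COc1ccc(-c2nc(SCC(=O)c3sc(-c4ccc(Cl)cc4)nc3C)[nH]c(=O)c2C#N)cc1OC` — 93.4%

In a functional assay on U-87MG ATCC cells for antiproliferative activity against U-87 MG (Homo sapiens), read by MTT assay, with a stated time of 48 h, tested at 5 uM (a higher number here means a weaker effect of the compound at the concentration tested, a lower number a stronger effect), compound 1 gives 101% and compound 2 gives 93.4%. Among the compounds with values here, on these two numbers compound 2 sits beside compound 1; the only step between them, a number 7.6 percentage points lower from compound 1 to compound 2 (within the scatter), is within the scatter, so neither compound can be set apart from the other, and both numbers show essentially no effect at the concentration tested.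

Compound 3 `Cc1nc(-c2ccc(Cl)cc2)sc1C(=O)CSc1nc(-c2ccc(Cl)cc2)c(C#N)c(=O)[nH]1` has not yet been measured. It differs from compound 2 in one place: 4-chlorophenyl in place of 3,4-dimethoxyphenyl on an aromatic carbon. Within the data shown here, the one measured step that bears on this change is a number 7.6 percentage points lower from compound 1 to compound 2 (within the scatter), in which a chlorinated phenyl gave way to the dimethoxyphenyl without a shift beyond the scatter. The change to compound 3 goes back toward a chlorinated phenyl, now 4-chlorophenyl, and the data give no ground to expect a larger response. Compound 3 is therefore expected to show a step of a number 4.6 percentage points higher from compound 2 to compound 3 (within the scatter), that is, none beyond the scatter. The estimate for compound 3 in this assay is 98%, within 86% to 110%.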

Compound 3, a percentage reported as activity, at one concentration (the size of the read-out at that concentration, not a potency): 99%
Compound 3: middle estimate off by 1 percentage points, on the low side, and the stated range covers the measured number.
By their numbers in this assay, from the lowest: compounds 2, 3 and 1 (each within the scatter of the next).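

In this assay, within the data shown here, the step of a number 5.6 percentage points higher from compound 2 to compound 3 (within the scatter) shows that exchanging 3,4-dimethoxyphenyl for the smaller 4-chlorophenyl, which carries no hydrogen-bond acceptors, on this aromatic carbon ortho to a cyano group leaves the read-out unresolved from that of the earlier compounds. The step of a number 2 percentage points lower from compound 1 to compound 3 (within the scatter) adds what the first pair could not show: with hydrogen in place of chloro on the aryl ring, one chloro or two at this position also makes no difference that can be read, so all three aryl groups give numbers within the scatter of one another and show essentially no effect at the concentration tested. Nothing available here explains this flat result, and no measurement beyond the read-out bears on it.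

All three compounds keep an unsubstituted-by-heteroatom-ring aryl group at this carbon, so the compounds shown leave open whether an amine, a carboxylic acid or a longer chain there would give a read-out outside the scatter. They also leave open whether changing the 4-chlorophenyl on the other side of the thioether, which all three share, would alter the number in this assay at all.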